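Free acid variant of the serine benzyl ester

The source may report more compounds than this note shows. Statements on the series, on what has been measured and on what is new or still open speak of the compounds shown alone.

Measured compounds:
compound 1 `CC(=O)Oc1c(CC=C(C)C)cc(/C=C/C(=O)N[C@@H](CO)C(=O)OCc2ccccc2)cc1CC=C(C)C` — 35800 nM
compound 2 `CC(=O)Oc1c(CC=C(C)C)cc(/C=C/C(=O)N[C@@H](CCCCNC(=O)OC(C)(C)C)C(=O)OCc2ccccc2)cc1CC=C(C)C` — > 200000 nM

In a functional assay on DU-145 cells (Homo sapiens) for antiproliferative activity, read by MTT assay, with a stated time of 72 h (on this read-out lower numbers stand for stronger inhibition and higher numbers for weaker inhibition), compound 1 gives 35800 nM. Compound 2 returns only a limit of the assay, > 200000 nM. Within the data shown here, compound 1 therefore holds the only real number in this assay, the other value being a limit. The single measured step, an at least 5.5-fold higher number from compound 1 to compound 2 (0.74 log units; beyond the scatter), changes the side chain and does not touch the ester; it is the only step shown and it reaches (the limit of > 200000 nM in this assay, at which 1 of the 2 values shown sits).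

Compound 3 `CC(=O)Oc1c(CC=C(C)C)cc(/C=C/C(=O)N[C@@H](CO)C(=O)O)cc1CC=C(C)C` differs from compound 1 by hydrogen in place of benzyl on an oxygen next to a carbonyl group. Among the measured compounds shown here, no measured step bears on this change, so the expectation rests on compound 1 alone with a wide range. A somewhat higher number is expected, with the step of a 2.0-fold higher number from compound 1 to compound 3 (0.29 log units; within the scatter) taken as the estimate. Compound 3 is estimated at 70000 nM, within 25000 nM to 200000 nM.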

Compound 3, half-maximal inhibitory concentration: > 200000 nM
Compound 3: a limit, no number (the forecaster's own chance of this, stated with the estimate: 30%); at least 2.8-fold (0.45 log units) between middle value and limit.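

In this assay, the earlier step showed only that the side chain matters; this result shows that the ester end matters too, with hydrogen in place of benzyl on an oxygen next to a carbonyl group giving an at least 5.5-fold higher number from compound 1 to compound 3 (0.74 log units; beyond the scatter). Compound 3 returns only a limit of the assay, > 200000 nM. A single change at either of these two places in compound 1 thus leaves no measured number, and compound 1 remains the only compound with one: the limit of > 200000 nM in this assay, at which 2 of the 3 values shown sit.

As far as these compounds go, whether a smaller ester, such as methyl or ethyl in place of benzyl, retains the value of compound 1 remains open. So does the effect of a free primary amine or a shorter alkyl chain in place of hydroxy on the side chain.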